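This account rests on a few compounds, and the source may have more. Where it says the series, first, only, none or still open, it means among the compounds named here.

Compound 1 `O=C(/C=C\Nc1ccc(F)cc1)c1cn(-c2ccccc2)nc1-c1ccc(F)cc1` gives 18200 nM in a functional assay on U-87MG ATCC cells (Homo sapiens) for antiproliferative activity, read by MTT assay, with a stated time of 48 h; a higher number here means a weaker inhibitor, a lower number a stronger inhibitor. Compound 2 `COc1ccc(-c2nn(-c3ccccc3)cc2C(=O)/C=C\Nc2ccc(F)cc2)cc1` gives 8910 nM in this assay, the lower of the two numbers, and the step of a 2.0-fold lower number from compound 1 to compound 2 (0.31 log units; beyond the scatter) lies beyond the scatter. Compound 3 `COc1ccc(N/C=C\C(=O)c2cn(-c3ccccc3)nc2-c2ccc(OC)cc2)cc1` differs from compound 2 by methoxy in place of fluoro on an aromatic carbon, the same exchange made again at a different site. For the measured compounds named here, only that one measured step bears on this change, and it was modest, so a modest lowering of the number is expected for compound 3 as well, a 1.5-fold lower number from compound 2 to compound 3 (0.17 log units; within the scatter). Compound 3 is therefore estimated at 6000 nM, within a range from 3000 nM to 15000 nM.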

Compound 3, half-maximal inhibitory concentration: > 50000 nM
Compound 3: no number, only a limit (the forecaster's own chance of this, stated with the estimate: 5%); middle value at least 8.3-fold (0.92 log units) away from the limit.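

Methoxy in place of fluoro on the (4-fluorophenyl)amino group gives an at least 5.6-fold higher number from compound 2 to compound 3 (0.74 log units; beyond the scatter), while the same exchange on the 4-fluorophenyl group gave a 2.0-fold lower number from compound 1 to compound 2 (0.31 log units; beyond the scatter). In these compounds, then, the direction of this exchange depends on the ring that carries it, so the first step did not carry over to the second site. Compound 3 gives a limit, not a number, in this assay: the limit of > 50000 nM in this assay, at which 1 of the 3 values shown sits.

The compounds shown leave open whether the higher number belongs to methoxy alone. A hydroxyl group or an amine at this site on the (4-fluorophenyl)amino group could help to separate that.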